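Nitrile in place of carboxy: tracheal potency notes

The source may report more compounds than this note shows. Statements on the series, on what has been measured and on what is new or still open speak of the compounds shown alone.

compound 1 `C=CCCn1c(=O)c2[nH]cnc2n(CCC)c1=O`: 200 nM
compound 2 `CCCn1c(=O)n(CC(=O)O)c(=O)c2[nH]cnc21`: 41000 nM

Within the data shown here, in a functional assay (trachea) with Cavia porcellus as the target (on this read-out higher numbers stand for an effect only at larger amounts of compound and lower numbers for an effect already at smaller amounts), compound 2 gives 41000 nM, the highest of the two numbers measured; its only neighbour is compound 1 at 200 nM, reached by a 210-fold higher number from compound 1 to compound 2 (2.31 log units; beyond the scatter). Compound 3 `CCCn1c(=O)n(CCC#N)c(=O)c2[nH]cnc21` differs from compound 2 by cyanomethyl in place of carboxy on a saturated chain carbon bound to an aromatic nitrogen. Among the measured compounds shown here, the only measured step bearing on this change is the one that brought the carboxy in, a 210-fold higher number from compound 1 to compound 2 (2.31 log units; beyond the scatter), a large step; taking the carboxy out again is therefore expected to move the number down substantially, though the entering cyanomethyl has no precedent here. For compound 3 the estimate in this assay is 2000 nM (range 400 nM to 10000 nM), an expected step of a 21-fold lower number from compound 2 to compound 3 (1.31 log units; beyond the scatter).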

Compound 3, half-maximal effective concentration: 1700 nM
Compound 3: the middle estimate sits 1.2-fold (0.07 log units) above what was measured; the measured number falls inside the stated range.
By their numbers in this assay, from the lowest: compound 1; then compound 3; then compound 2.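

Replacing the carboxy with cyanomethyl at this position in this assay gives a 24-fold lower number from compound 2 to compound 3 (1.38 log units; beyond the scatter) and so recovers much of the potency lost with the carboxymethyl chain. The chain on this nitrogen therefore tolerates a polar-free change only in part: the 2-cyanoethyl group still does not match the chain of compound 1, with an 8.5-fold higher number from compound 1 to compound 3 (0.93 log units; beyond the scatter) remaining between them. No measurement given here explains either step.

Open, going by these compounds, is whether a primary amide or an amine at the chain end would behave like the nitrile or the carboxy. Also open, on these data alone, is whether a longer chain ending in nitrile would close the remaining gap to compound 1.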